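Adding Methoxy to a Sulfoxide-Bearing Inhibitor

A few compounds are considered here, and "the series" means these few. Any claim that something is new, unique, unknown or untested is made for them only; others in the source may bear on it.

Measured so far in a functional assay on DLD-1 cells (Homo sapiens) for inhibition, with a stated time of 48 h; a higher number here means a weaker inhibitor, a lower number a stronger inhibitor:

Compound 1 `COc1cc2oc(/C=C/[S+](C)[O-])cc(=O)c2cc1OC` gives 4200 nM
Compound 2 `C[S+]([O-])/C=C/c1cc(=O)c2ccccc2o1` gives 1000 nM

Of these two, compound 2 has the lower number and so is the stronger inhibitor, and the gap to compound 1 lies beyond the usual scatter. Compound 3 `COc1ccc2oc(/C=C/[S+](C)[O-])cc(=O)c2c1` has not yet been measured. It carries one change from compound 2, methoxy in place of hydrogen on an aromatic carbon. Going by the values given here, no measured pair isolates this change. Among the compounds with values here, the only guide is that compound 1, which also bears methoxy, stands at 4200 nM against the lower number of compound 2, and two compounds establish no rule. A small rise in the number is therefore expected, and the estimated step is a 2.0-fold higher number from compound 2 to compound 3 (0.30 log units; within the scatter) and lies near the edge of the scatter. In this assay compound 3 is expected at 2000 nM (estimated range 700 nM to 6000 nM).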

Compound 3, half-maximal inhibitory concentration: 1100 nM
Estimate against measurement, compound 3: 1.8-fold (0.26 log units) above, within the range that was stated.
By their numbers in this assay, from the lowest: compounds 2 and 3 (each within the scatter of the next); then compound 1.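

With a 1.1-fold higher number from compound 2 to compound 3 (0.04 log units; within the scatter), methoxy in place of hydrogen on the aromatic carbon meta to a fused ring and para to a fused ring has no effect that can be told from the scatter in this assay. The higher number of compound 1 therefore does not go with every methoxy on the shared core: a 3.8-fold lower number from compound 1 to compound 3 (0.58 log units; beyond the scatter), with hydrogen in place of methoxy on an aromatic carbon, lies beyond the scatter, so the gap goes with the methoxy that compound 1 holds and compound 3 lacks. No measurement at hand explains either step.

The compounds shown leave open whether this carbon would take an amine, a carboxylic acid or a longer alkoxy chain as it takes methoxy. They also leave open whether the other methoxy of compound 1, alone on the core of compound 2, would give the same gap.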